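Urea series: configuration change at the chain carbon

The compounds below may be only part of what the source reports. "The series", "measured", "known", "first", "only" and "open" are said of these compounds alone.

Measured compounds and their values in an ADME assay on the whole organism with Oryza sativa as the target, tested at 1 uM; on this read-out lower numbers stand for a stronger effect and higher numbers for a weaker effect at the one concentration tested:
compound 1 `Cc1ccc(NC(=O)N[C@@H](C)c2ccccc2)cc1` — 99%
compound 2 `CCOC(=O)c1ccc(NC(=O)N[C@H](C)c2ccccc2)cc1` — 100%

In this assay compound 2 gives 100%, the highest of the two numbers; its nearest neighbour, compound 1, gives 99%, which lies within the scatter of the number for compound 2. Both read-outs therefore stand at the weak end of the scale, and no difference between them can be claimed.

Within the data shown here, compound 3 `CCOC(=O)c1ccc(NC(=O)N[C@@H](C)c2ccccc2)cc1` has not yet been measured. the two compounds have the same atoms and bonds and differ only in configuration as drawn: 1 of 1 stereo elements differ; a stereocentre at a saturated chain carbon is drawn R in compound 2 and S in compound 3 No step between measured compounds of this kind is available, so the size of the change can only be expected. Compound 3 is drawn with the same configuration as compound 1, which gives 99% in this assay, and both measured values sit near the top of the scale, so a step of a number 1 percentage points lower from compound 2 to compound 3 (within the scatter) is expected, that is none beyond the scatter. Compound 3 is estimated at 99%, within a range from 90% to 100%.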

Compound 3, a percentage reported as activity, at one concentration (the size of the read-out at that concentration, not a potency): 97%
Beside the measured number, compound 3's estimate is 2 percentage points above it; the range from low to high includes it.
By their numbers in this assay, from the lowest: compounds 3, 1 and 2 (each within the scatter of the next).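

In this assay, inverting the stereocentre at the saturated chain carbon gives a number 3 percentage points lower from compound 2 to compound 3 (within the scatter), so configuration at this position shows no effect that can be told from the scatter. This step can be read as one of configuration alone because nothing else separates the pair: the fact that compounds 2 and 3 differ only in the configuration as drawn

With the configuration held, ethoxycarbonyl in place of methyl on an aromatic carbon gives a number 2 percentage points lower from compound 1 to compound 3 (within the scatter), so that change also stays inside the scatter, and neither place has yet been shown to move this read-out from the weak end of the scale.

Open, from the compounds shown here alone, is whether a carboxylic acid or an amine in place of ethoxycarbonyl on the aromatic carbon, or a longer chain at the chain carbon, would bring the read-out away from the weak end. Also open, going by these compounds, is whether configuration at the chain carbon would count in such a compound.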